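Piperazine nitrogen substituent in the amide series

This account rests on a few compounds, and the source may have more. Where it says the series, first, only, none or still open, it means among the compounds named here.

Compound 1 `COc1ccc([C@@H](CCCN(C)S(=O)(=O)c2cccs2)N2Cc3c(cccc3N3CCN(C4CCC4)CC3)C2=O)cc1OC` gives 44 nM in an assay on RMS13 cells for displacement of a labelled ligand from Urotensin-2 receptor (Homo sapiens), read by scintillation proximity assay; a lower number here means a stronger inhibitor, a higher number a weaker inhibitor. Compound 2 `COc1ccc([C@@H](CCCN(C)S(=O)(=O)c2cccs2)N2Cc3c(cccc3N3CCN(C)CC3)C2=O)cc1OC` differs only in the group on the ring nitrogen; its result in this assay, < 6 nM, is a limit of the assay and not a number. The step of an at least 7.3-fold lower number from compound 1 to compound 2 (0.86 log units; beyond the scatter) is known only as a lower bound on its size. Compound 2 sits at the limit (the limit of < 6 nM in this assay, at which 1 of the 2 values shown sits); its true position among the measured numbers is open, and it lies under compound 1 by an unknown margin.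

Compound 3 `COc1ccc([C@@H](CCCN(C)S(=O)(=O)c2cccs2)N2Cc3c(cccc3N3CCNCC3)C2=O)cc1OC` is the next cut in the same place: hydrogen in place of methyl on an amine nitrogen in a ring. For the measured compounds named here, the only measured step that bears on it is an at least 7.3-fold lower number from compound 1 to compound 2 (0.86 log units; beyond the scatter), where the smaller group on that nitrogen gave the stronger inhibitor. Compound 3 is expected to remain at or near the limit, with a step that the limit leaves unreadable from compound 2 to compound 3 not beyond the scatter. The expected value for compound 3 is 4 nM, within 1.5 nM to 12 nM.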

Compound 3, inhibition constant: 49 nM
Estimate against measurement, compound 3: 12-fold (1.09 log units) below; the measured number lies above the stated range.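

At this ring nitrogen, the trend toward smaller groups does not carry through to hydrogen. Going from 4-methylpiperazin-1-yl to piperazin-1-yl gives an at least 8.1-fold higher number from compound 2 to compound 3 (0.91 log units; beyond the scatter), which reverses the direction of an at least 7.3-fold lower number from compound 1 to compound 2 (0.86 log units; beyond the scatter). Hydrogen and cyclobutyl stand level, with a 1.1-fold higher number from compound 1 to compound 3 (0.05 log units; within the scatter), so among these three compounds in this assay, only the methyl of compound 2 stands apart, and the response does not follow the size of the group in a single direction. The result for compound 2 is a limit of the assay and not a number, so both steps to it give only a lower bound on their size: the limit of < 6 nM in this assay, at which 1 of the 3 values shown sits.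

As far as these compounds go, the true value of compound 2 remains open, and with it the full size of the methyl advantage. From the compounds shown here alone, it is also open whether that advantage is particular to methyl or extends to an ethyl, an isopropyl or an acetyl group on the same nitrogen.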